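From ethoxy to 2,4-difluorophenyl on a carbonyl carbon

The source may hold more compounds than are shown below. What is called first, only, known or untested is meant among the compounds shown, and "the series" means these compounds.

In a functional assay on WI-38 VA13 cells (Homo sapiens) for cytotoxicity (on this read-out lower numbers stand for an effect already at smaller amounts and higher numbers for an effect only at larger amounts of compound), compound 2 `CCOC(=O)c1sc2nc(-c3cccs3)ccc2c1N` gives > 4 ug/mL, which is a limit of the assay and not a number. Compound 3 `Nc1c(C(=O)c2ccc(F)cc2)sc2nc(-c3cccs3)ccc12` reads 1.8 ug/mL, and compound 1 `COc1ccc(C(=O)c2sc3nc(-c4cccs4)ccc3c2N)cc1` reads 0.77 ug/mL. Compound 4 `Nc1c(C(=O)c2ccc(F)cc2F)sc2nc(-c3cccs3)ccc12` departs from compound 2 on a carbonyl carbon, where 2,4-difluorophenyl stands in place of ethoxy: 2,4-difluorophenyl in place of ethoxy on a carbonyl carbon.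

The nearest measured precedent is an at least 2.2-fold lower number from compound 2 to compound 3 (0.34 log units; beyond the scatter), where 4-fluorophenyl replaced ethoxy at the same place. The swap between ethoxy and 4-methoxyphenyl points the same way, with an at least 5.1-fold higher number from compound 1 to compound 2 (0.71 log units; beyond the scatter). The choice of phenyl substituent also counts, as a 2.3-fold higher number from compound 1 to compound 3 (0.37 log units; beyond the scatter) shows. Both measured steps from ethoxy to a substituted phenyl therefore favour a lower number in this assay, of modest size, although the limit on compound 2 leaves the true size open. The expected change is an at least 2.5-fold lower number from compound 2 to compound 4 (0.39 log units; beyond the scatter). For compound 4 the estimate is 1.6 ug/mL, with an expected range of 0.7 ug/mL to 3.8 ug/mL.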

Compound 4, half-maximal effective concentration: 2.3 ug/mL
Compound 4: the middle estimate sits 1.4-fold (0.16 log units) below what was measured; low and high end bracket the measured number.
By their numbers in this assay, from the lowest: compound 1; then compounds 3 and 4 (each within the scatter of the next). At a limit, above all of these: compound 2.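

In this assay, fluoro in place of hydrogen on an aromatic carbon of the phenyl group makes no difference that can be told apart from scatter, with a 1.3-fold higher number from compound 3 to compound 4 (0.11 log units; within the scatter). The 4-methoxyphenyl group keeps its lead over this new group too, with a 3.0-fold higher number from compound 1 to compound 4 (0.48 log units; beyond the scatter), so among the compounds shown, the methoxy-bearing group gives the lowest number at this carbonyl carbon. The step from the ester reads as an at least 1.7-fold lower number from compound 2 to compound 4 (0.24 log units; that floor lies within the scatter), and this floor alone cannot settle the size of the change, since the value of compound 2 is a limit of the assay: the limit of > 4 ug/mL in this assay, at which 1 of the 4 values shown sits.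

The compounds shown leave open how an amine or a hydroxy group would read in place of methoxy on that aromatic carbon. They also leave open how an amide or a longer ester chain would read in place of ethoxy on the carbonyl carbon.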